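The source may report more compounds than this note shows. Statements on the series, on what has been measured and on what is new or still open speak of the compounds shown alone.

Measured compounds:
- compound 1, `CC1(c2ccccc2)CC(=O)N(CC(=O)N2CCN(c3ccccc3)CC2)C1=O`: 300 mg/kg
- compound 2, `CC1(c2ccccc2)CC(=O)N(CC(=O)N2CCN(c3ccc(Cl)c(Cl)c3)CC2)C1=O`: "not active" (no number reported)

In a functional assay on the whole organism (strain CD-1) with Mus musculus as the target, in the maximal electroshock model, with a stated time of 0.5 h (on this read-out lower numbers stand for an effect already at smaller amounts and higher numbers for an effect only at larger amounts of compound), compound 1 gives 300 mg/kg. Compound 2, which carries the 3,4-dichlorophenyl group, is reported in this assay only as "not active" (no number reported), so no single number stands for it and no distance between compound 1 and compound 2 can be given. Compound 3, `CC1(c2ccccc2)CC(=O)N(CC(=O)N2CCN(c3ncccn3)CC2)C1=O`, has not been tested. It differs from compound 2 by pyrimidin-2-yl in place of 3,4-dichlorophenyl on an amine nitrogen in a ring. Among the compounds with values here, because compound 2 gives "not active" (no number reported), the step to compound 3 cannot be expressed as a measured difference; compound 1 with its phenyl group is the only anchor with a number. Compound 3 is therefore expected to fall roughly where compound 1 stands, with a real chance that, like compound 2, it yields no number at all. The estimate for compound 3 is 300 mg/kg, expected between 100 mg/kg and 600 mg/kg.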

Compound 3, minimum effective dose: "not active" (no number reported)
Compound 3: no number reported; no gap can be computed for the estimate.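

In this assay, within the data shown here, compound 2 gives "not active" (no number reported) and compound 3 gives "not active" (no number reported), and no step between them can be read. The compounds shown leave open how pyrimidin-2-yl and 3,4-dichlorophenyl compare on this read-out. No supporting evidence bears on this result.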